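The source may report more compounds than this note shows. Statements on the series, on what has been measured and on what is new or still open speak of the compounds shown alone.

Measured so far:
compound 1, `COc1cc(N)c(Cl)cc1C(=O)NC1CCN(CCCCCN2C(=O)c3ccccc3C2=O)CC1`: in an assay on HEK293 cells for displacement of a labelled ligand from 5-hydroxytryptamine receptor 4 (Homo sapiens), read by scintillation counting (on this read-out higher numbers stand for weaker inhibition and lower numbers for stronger inhibition), compound 1 gives 20 nM
compound 2, `COc1cc(N)c(Cl)cc1C(=O)NC1CCN(CCCCCCCCN2CCCCC2)CC1`: in this assay compound 2 gives 3.16 nM

Among the measured compounds shown here, compound 2 stands at the lowest of the two numbers; the only step seen is a 6.3-fold lower number from compound 1 to compound 2 (0.80 log units; beyond the scatter). Compound 3, `COc1cc(N)c(Cl)cc1C(=O)NC1CCN(CCCCCN2CCN(S(C)(=O)=O)CC2)CC1`, differs from compound 2 in this way: 4-(methylsulfonyl)piperazin-1-yl in place of 3-(piperidin-1-yl)propyl on a saturated chain carbon, five bonds along the chain from an amine nitrogen in a ring. That single step is the only one that bears on such a change at the end of the chain, and it was modest. With no closer comparison, the expected step is a 2.5-fold higher number from compound 2 to compound 3 (0.40 log units; beyond the scatter). For compound 3 the estimate is 8 nM, with a range from 2.5 nM to 25 nM.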

Compound 3, inhibition constant: 39.8 nM
Compound 3: the middle estimate sits 5.0-fold (0.70 log units) below what was measured; the whole stated range lies below it.
By their numbers in this assay, from the lowest: compound 2; then compounds 1 and 3 (each within the scatter of the next).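

In this assay, 4-(methylsulfonyl)piperazin-1-yl in place of 3-(piperidin-1-yl)propyl gives a 13-fold higher number from compound 2 to compound 3 (1.10 log units; beyond the scatter) and so a large step, showing that the group on this saturated chain carbon can move the number well beyond the scatter. Yet very different groups here need not differ, as a 2.0-fold higher number from compound 1 to compound 3 (0.30 log units; within the scatter) shows when the methylsulfonyl piperazine replaces the group of compound 1. No measurement at hand accounts for either step.

The compounds shown leave open how a plain piperazine without the methylsulfonyl group, or a morpholine ring, would read at this place, and so which part of the entering group goes with the large step.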